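The source may report more compounds than this note shows. Statements on the series, on what has been measured and on what is new or still open speak of the compounds shown alone.

Measured in an ADME assay on MT4 cells (Homo sapiens) for cytotoxicity, read by MTT assay; on this read-out lower numbers stand for higher toxicity in this test and higher numbers for lower toxicity in this test:
- compound 1 `Cc1cccc(C(=O)N(C(=S)OCCN2C(=O)c3ccccc3C2=O)c2ccc(Cl)cc2)c1`: 58000 nM
- compound 2 `O=C1c2ccccc2C(=O)N1CCOC(=S)N(C(=O)c1cccc(F)c1F)c1ccc(Cl)cc1`: 58000 nM
- compound 3 `O=C1c2ccccc2C(=O)N1CCOC(=S)N(C(=O)c1ccc(F)c(F)c1)c1ccc(Cl)cc1`: 52000 nM

All three numbers in this assay sit within the usual scatter of one another; compound 3 is the lowest of the three only by a margin that means nothing, as a 1.1-fold lower number from compound 1 to compound 3 (0.05 log units; within the scatter) and a 1.1-fold lower number from compound 2 to compound 3 (0.05 log units; within the scatter) show, and no change at the digits printed from compound 1 to compound 2 (within the scatter) is flat as well. Compound 4 `O=C1c2ccccc2C(=O)N1CCOC(=S)N(C(=O)c1cc([N+](=O)[O-])ccc1Cl)c1ccc(Cl)cc1` is not yet measured. It differs from compound 3 by 2-chloro-5-nitrophenyl in place of 3,4-difluorophenyl on a carbonyl carbon. Within the data shown here, every measured step so far swaps the aryl group on this carbonyl carbon, and none of them moved this assay beyond the scatter. The same is therefore expected here: compound 4 is estimated at 50000 nM (range 25000 nM to 100000 nM), with an expected step of a 1.0-fold lower number from compound 3 to compound 4 (0.02 log units; within the scatter).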

Compound 4, half-maximal cytotoxic concentration: 45000 nM
The estimate for compound 4 lay 1.1-fold (0.05 log units) above the measured number; the measured number falls inside the stated range.
By their numbers in this assay, from the lowest: compounds 4, 3, 1 and 2 (each within the scatter of the next).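

In this assay the series reads a 1.2-fold lower number from compound 3 to compound 4 (0.06 log units; within the scatter) and a 1.3-fold lower number from compound 2 to compound 4 (0.11 log units; within the scatter) and a 1.3-fold lower number from compound 1 to compound 4 (0.11 log units; within the scatter) with each step within the scatter. On this carbonyl carbon, the read-out therefore stays flat even with 2-chloro-5-nitrophenyl, which brings 2 hydrogen-bond acceptors and a double bond outside aromatic rings that 3,4-difluorophenyl lacks. Nothing available accounts for this flatness.

Still open, as far as these compounds go, is whether a carboxylic acid or an amine on the aryl ring would shift the number. Also open, from the compounds shown here alone, is whether a longer alkyl chain in place of the aryl group would do so.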